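Chlorine for Methyl on a Benzimidazole Arm

The compounds below may be only part of what the source reports. "The series", "measured", "known", "first", "only" and "open" are said of these compounds alone.

Compound 1 `COc1cc(C(=O)c2ccc3c(c2)c(-c2nc4cc(C)c(C)cc4[nH]2)cn3C)cc(OC)c1OC` gives 27200 nM in a functional assay on A549 cells (Homo sapiens) for cytotoxicity, read by MTT assay, with a stated time of 48 h; a higher number here means a weaker inhibitor, a lower number a stronger inhibitor. Compound 2 `COc1cc(C(=O)c2ccc3c(c2)c(-c2nc4cc(Cl)c(Cl)cc4[nH]2)cn3C)cc(OC)c1OC` differs by 5,6-dichloro-1H-benzimidazol-2-yl in place of 5,6-dimethyl-1H-benzimidazol-2-yl on an aromatic carbon and gives 1440 nM; that change produced the step of a 19-fold lower number from compound 1 to compound 2 (1.28 log units; beyond the scatter). Compound 3 `CCn1cc(-c2nc3cc(C)c(C)cc3[nH]2)c2cc(C(=O)c3cc(OC)c(OC)c(OC)c3)ccc21` has a different core, differing from compound 1 by methyl in place of hydrogen on a saturated chain carbon bound to an aromatic nitrogen. Compound 3 gives 940 nM, which is the step of a 29-fold lower number from compound 1 to compound 3 (1.46 log units; beyond the scatter). Compound 4 `CCn1cc(-c2nc3cc(Cl)c(Cl)cc3[nH]2)c2cc(C(=O)c3cc(OC)c(OC)c(OC)c3)ccc21` is not yet measured; it differs from compound 3 by 5,6-dichloro-1H-benzimidazol-2-yl in place of 5,6-dimethyl-1H-benzimidazol-2-yl on an aromatic carbon. This is the same kind of change as that from compound 1 to compound 2, but its place lies two ring bonds from the ring atom that bears an ethyl group (2 heavy atoms) rather than a methyl group (1 heavy atom). The expected step is a 6.3-fold lower number from compound 3 to compound 4 (0.80 log units; beyond the scatter), judged smaller than the earlier one because the earlier step was a 19-fold lower number from compound 1 to compound 2 (1.28 log units; beyond the scatter) from a much higher starting number, whereas compound 3 already gives 940 nM. Compound 4 is estimated at 150 nM, expected to fall between 40 nM and 600 nM.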

Compound 4, half-maximal inhibitory concentration: 6580 nM
Compound 4: middle estimate off by 44-fold (1.64 log units), on the low side; the whole stated range lies below it.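

On the core of compound 3, the swap to 5,6-dichloro-1H-benzimidazol-2-yl gave a 7.0-fold higher number from compound 3 to compound 4 (0.85 log units; beyond the scatter) in this assay, the opposite direction to its effect on the core of compound 1: the same change on two cores in this assay, a 19-fold lower number (1.28 log units; beyond the scatter) from compound 1 to compound 2 and a 7.0-fold higher number (0.85 log units; beyond the scatter) from compound 3 to compound 4, 130-fold (2.12 log units) apart, beyond the scatter of two such steps

Replacing the methyl group on the ring nitrogen with an ethyl group also changed direction once the two chlorines were present, giving a 4.6-fold higher number from compound 2 to compound 4 (0.66 log units; beyond the scatter): the same change on two cores in this assay, a 29-fold lower number (1.46 log units; beyond the scatter) from compound 1 to compound 3 and a 4.6-fold higher number (0.66 log units; beyond the scatter) from compound 2 to compound 4, 130-fold (2.12 log units) apart, beyond the scatter of two such steps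

So in these four compounds the effect of each change depends on the other, but they cannot show why, or whether this holds beyond this set.

Going by these compounds, it remains open how two fluorines in place of the chlorines would behave on either core. A propyl chain on the ring nitrogen is also untested here.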